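A few compounds are considered here, and "the series" means these few. Any claim that something is new, unique, unknown or untested is made for them only; others in the source may bear on it.

Measured compounds:
- compound 1 `O=C(Nc1ccc(OC(F)(F)F)cc1)NC1CCN(C(=O)c2ccoc2)CC1`: 3.63
- compound 2 `O=C(Nc1ccc(C(F)(F)F)cc1)NC1CCN(C(=O)c2ccoc2)CC1`: 3.5
- compound 3 `O=C(Nc1ccc(OC(F)(F)F)c(F)c1)NC1CCN(C(=O)C2(C(F)(F)F)CC2)CC1`: 5.94

In a physicochemical assay for lipophilicity, read by HPLC, with a stated time of 90 min, tested at 100 uM (on this read-out higher numbers stand for higher lipophilicity and lower numbers for lower lipophilicity), compound 2 gives the lowest of the three numbers. Its nearest neighbour is compound 1, reached by a number 0.13 log units lower from compound 1 to compound 2 (within the scatter), so the two compounds cannot be told apart on this read-out. Compound 3 stands far higher, but it differs from compound 2 in several places at once, so its value says nothing about any single change.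

Compound 4 `O=C(Nc1ccc(C(F)(F)F)cc1)NC1CCN(C(=O)[C@@H]2CCOC2)CC1` is the next compound and has not yet been measured. It differs from compound 2 in one place: oxolan-3-yl in place of furan-3-yl on a carbonyl carbon

Among the compounds with values here, none of the measured steps bears on this change. Within the data shown here, the only single-place step, from compound 1 to compound 2, concerns a different part of the molecule, and the gap between compound 2 and compound 3 mixes several changes. The expectation for compound 4 therefore rests on the counted difference alone, trading a five-membered aromatic ring for a five-membered non-aromatic ring with the same hetero atom and the same acceptor count. The step of a number 0.30 log units lower from compound 2 to compound 4 (within the scatter) is expected to be modest and downward, near the edge of the scatter. Compound 4 is thus estimated at 3.2, within 2.7 to 3.7.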

Compound 4, partition coefficient: 3.27
The estimate for compound 4 lay 0.07 log units below the measured number, within the range that was stated.
By their numbers in this assay, from the lowest: compounds 4, 2 and 1 (each within the scatter of the next, the first and the last beyond it); then compound 3.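

Within the data shown here, with a number 0.23 log units lower from compound 2 to compound 4 (within the scatter), this assay gives the first direct reading at this place, on a carbonyl carbon whose other neighbour is an amide-type nitrogen in a ring, which the earlier compounds, differing elsewhere or in several places at once, could not provide. Oxolan-3-yl in place of furan-3-yl replaces a five-membered aromatic ring with a five-membered non-aromatic ring and brings in a defined stereocentre, while the counted heavy atoms, hetero atom and hydrogen-bond acceptor stay the same, and on this read-out compound 2 and compound 4 cannot be told apart. No measurement is available that would explain this outcome.

As far as these compounds go, it remains open whether the other stereoisomer of the oxolan-3-yl group would read the same as compound 4, and whether an amine, a carboxylic acid or an open methoxyethyl chain on the same carbonyl carbon would give a step beyond the scatter. From the compounds shown here alone, it also remains open whether the same exchange of rings would read alike on the core of compound 1, which carries trifluoromethoxy in place of trifluoromethyl.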